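Working notes: from compound 3 to compound 4

The source may report more compounds than this note shows. Statements on the series, on what has been measured and on what is new or still open speak of the compounds shown alone.

Measured in a physicochemical assay for solubility, at pH 7.4 (on this read-out higher numbers stand for higher solubility and lower numbers for lower solubility), as follows:
- compound 1 `CCCCNc1nc(N)c2nc(O)n(Cc3ccc(C)cc3)c2n1` gives < 1000 ug/mL as a limit, not a number
- compound 2 `CCCCNc1nc(N)c2[nH]c(=O)n(Cc3ccc(N4CCN(C)CC4)cc3)c2n1` gives 108000 ug/mL as a number
- compound 3 `CCCCNc1nc(N)c2[nH]c(=O)n(Cc3ccc(OCCCCN(C)C)nc3)c2n1` gives 350000 ug/mL as a number

Compound 3 at 350000 ug/mL holds the highest of the two numbers. Compound 2 at 108000 ug/mL lies lower, and the gap between the two is beyond the scatter. The value of compound 1 is a limit.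

Compound 4 `CCCCNc1nc(N)c2[nH]c(=O)n(Cc3ccc(N4CCN(C)CC4)nc3)c2n1` has 4-methylpiperazin-1-yl in place of the 4-(dimethylamino)butoxy of compound 3 on an aromatic carbon, next to the ring nitrogen 4-methylpiperazin-1-yl in place of 4-(dimethylamino)butoxy on an aromatic carbon and keeps the rest of the structure. Going by the values given here, no two measured compounds differ in one place only, so no measured step guides this change. Compound 4 and compound 2 both carry 4-methylpiperazin-1-yl on different aromatic rings, so the expectation leans towards compound 2 at 108000 ug/mL but stays somewhat higher. The estimated step in this assay is downward and modest, expected at a 2.3-fold lower number from compound 3 to compound 4 (0.37 log units; beyond the scatter) and only just beyond the scatter. For compound 4 the estimated value is 150000 ug/mL with an expected range from 60000 ug/mL to 400000 ug/mL on this read-out.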

Compound 4, solubility: 7000 ug/mL
The estimate for compound 4 lay 21-fold (1.33 log units) above the measured number; measured number outside the range, below it.
By their numbers in this assay, from the lowest: compound 4; then compound 2; then compound 3. At a limit, below all of these: compound 1.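

Working notes on the series, after compound 4.

In this assay, going by these compounds alone, the exchange of 4-(dimethylamino)butoxy for 4-methylpiperazin-1-yl on an aromatic carbon next to the ring nitrogen gives a 50-fold lower number from compound 3 to compound 4 (1.70 log units; beyond the scatter), the first change in one place, and it shows that the read-out is highly sensitive to the group at this position. The leaving and entering groups have the same counts of hydrogen-bond donors and acceptors, so these counts do not separate them, and 4-methylpiperazin-1-yl does not fix the value on its own: compound 2, which carries it on a different aromatic ring, gives 108000 ug/mL, whereas compound 4 gives 7000 ug/mL. Compound 1 alone sits at a limit, and neither compound in this step reaches it: the limit of < 1000 ug/mL in this assay, at which 1 of the 4 values shown sits.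

The compounds shown do not separate the role of the open chain from that of the ether oxygen or the non-aromatic ring. On these data alone, whether a morpholin-4-yl group or a shorter 2-(dimethylamino)ethoxy chain on this aromatic carbon would stand nearer to compound 3 or to compound 4 remains open.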